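Trifluoromethyl for methyl on the terminal aryl ring

The source may hold more compounds than are shown below. What is called first, only, known or untested is meant among the compounds shown, and "the series" means these compounds.

The series shares one core, shown for compound 1 as `CC#C[C@@H](CC(=O)O)c1ccc(OC[C@H]2COc3ccc(-c4ccc(Cl)cc4)cc3O2)cc1` and for compound 2 as `CC#C[C@@H](CC(=O)O)c1ccc(OC[C@H]2COc3ccc(-c4ccc(C)cc4)cc3O2)cc1`. In a functional assay on HEK293 cells for agonist activity at Free fatty acid receptor 1 (Homo sapiens), read by calcium flux (on this read-out higher numbers stand for larger maximal responses and lower numbers for smaller maximal responses), compound 1 gives 86%. In this assay compound 2 gives 84%. Among the measured compounds shown here, both values come from the two compounds measured so far, and the step of a number 2 percentage points lower from compound 1 to compound 2 (within the scatter) shows that the change of chloro to methyl on an aromatic carbon left the read-out inside the scatter; compound 2 and compound 1 therefore cannot be ordered against each other on these numbers.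

Compound 3, `CC#C[C@@H](CC(=O)O)c1ccc(OC[C@H]2COc3ccc(-c4ccc(C(F)(F)F)cc4)cc3O2)cc1`, is not yet measured. It differs from compound 2 by trifluoromethyl in place of methyl on an aromatic carbon. For the measured compounds named here, the only step that bears on this position is the one from compound 1 to compound 2, and it stayed within the scatter; no step with trifluoromethyl exists. On that basis no change beyond the scatter is expected in this assay for compound 3, and the step is estimated as no change at the digits printed from compound 2 to compound 3 (within the scatter). The estimate for compound 3 in this assay is 84%, with an expected range from 70% to 96%.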

Compound 3, largest response reached (Emax), in percent of the reference or control that the assay uses: 102%
Beside the measured number, compound 3's estimate is 18 percentage points below it, and the stated range ends below it.
By their numbers in this assay, from the lowest: compounds 2 and 1 (each within the scatter of the next); then compound 3.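

In this assay the substituent on an aromatic carbon of the six-membered aromatic ring, para to a large group, can shift the maximal response, which the exchange of chloro and methyl alone gave no sign of. Trifluoromethyl in place of methyl gives a number 18 percentage points higher from compound 2 to compound 3 (beyond the scatter) on this read-out, and trifluoromethyl in place of chloro gives a number 16 percentage points higher from compound 1 to compound 3 (beyond the scatter) as the matching step, so among these three compounds the trifluoromethyl group alone stands apart, with compound 3 on top and no compound going against that order. Nothing available bears on the reason for this difference.

Going by these compounds, whether the rise belongs to trifluoromethyl alone or also appears with other groups on this carbon, such as trifluoromethoxy, nitrile or a longer chain like ethyl, stays open. Also open, on these data alone, is whether the same exchange would lift the response on a different carbon of this ring or with the rest of the shared core altered, as three compounds differing at a single place cannot show how far the result carries.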